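Swapping a nitrobenzyl for a trifluoromethylphenyl on the core

The compounds below may be only part of what the source reports. "The series", "measured", "known", "first", "only" and "open" are said of these compounds alone.

Of the compounds shown here, three sharing one core have been tested in a functional assay on BJAB cells (Homo sapiens) for antiproliferative activity, with a stated time of 4 days; on this read-out higher numbers stand for an effect only at larger amounts of compound and lower numbers for an effect already at smaller amounts. Compound 1 `COc1cc(-c2c(C)nn(-c3nc(-c4ccc(Cl)c(Cl)c4)c(SC(C)C)s3)c2C(=O)O)cc(C(F)(F)F)c1` gives 1380 nM. Compound 2 `Cc1cc(-c2c(C)nn(-c3nc(-c4ccc(Cl)c(Cl)c4)c(SC(C)C)s3)c2C(=O)O)cc(C)n1` gives 580 nM, a step of a 2.4-fold lower number from compound 1 to compound 2 (0.38 log units; beyond the scatter). Compound 3 `Cc1nn(-c2nc(-c3ccc(Cl)c(Cl)c3)c(SC(C)C)s2)c(C(=O)O)c1Cc1ccccc1[N+](=O)[O-]` gives 20000 nM, the highest number of the three: its number lies a 14-fold higher number from compound 1 to compound 3 (1.16 log units; beyond the scatter) and a 34-fold higher number from compound 2 to compound 3 (1.54 log units; beyond the scatter), so both measured steps toward it were large and both went toward weaker activity when the aromatic ring attached to the core was replaced by a 2-nitrobenzyl.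

Compound 4 `Cc1nn(-c2nc(-c3ccc(Cl)c(Cl)c3)c(SC(C)C)s2)c(C(=O)O)c1-c1ccccc1C(F)(F)F` takes the opposite kind of step. The change is 2-(trifluoromethyl)phenyl in place of 2-nitrobenzyl on an aromatic carbon. The aromatic ring is once more joined to the core as in compounds 1 and 2, though with a different substituent than either of them. The two large steps into compound 3 suggest that leaving it should lower the number markedly, and a large drop is therefore expected for compound 4 in this assay, estimated as a 10-fold lower number from compound 3 to compound 4 (1.00 log units; beyond the scatter). Compound 4 is estimated at 2000 nM, in a range from 500 nM to 8000 nM.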

Compound 4, half-maximal effective concentration: 5200 nM
Compound 4: middle estimate off by 2.6-fold (0.41 log units), on the low side, within the range that was stated.
By their numbers in this assay, from the lowest: compound 2; then compound 1; then compound 4; then compound 3.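

In this assay, among these compounds, 2-(trifluoromethyl)phenyl in place of 2-nitrobenzyl regains only part of the gap (a 3.8-fold lower number from compound 3 to compound 4 (0.59 log units; beyond the scatter)), so an aromatic ring joined straight to the core does not by itself bring the number back to those of the earlier compounds. Which ring sits at this position also matters, since compound 4 remains clearly weaker than both other compounds with a directly joined ring (a 3.8-fold higher number from compound 1 to compound 4 (0.58 log units; beyond the scatter); a 9.0-fold higher number from compound 2 to compound 4 (0.95 log units; beyond the scatter)). Nothing available explains these differences.

Compound 2 differs from compounds 1 and 4 in both its ring nitrogen and its two methyl groups, so the compounds shown do not separate the contributions of these features. Unsubstituted phenyl and a pyridine ring carrying no methyl groups at this position would be the simplest comparisons to draw those contributions apart.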